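This account rests on a few compounds, and the source may have more. Where it says the series, first, only, none or still open, it means among the compounds named here.

Measured compounds:
Compound 1 `CC1=C(N2CC2)C(=O)C(CC(C)OC(N)=O)=C(N2CC2)C1=O` — 5.79
Compound 2 `CCCC1=C(N2CC2)C(=O)C(CCC)=C(N2CC2)C1=O` — 4.44

In a functional assay on L1210 cells (Mus musculus), with a stated time of 12 days (a higher number here means a more potent compound, by a factor of ten per unit of this negative logarithm, a lower number a less potent compound), compound 1 gives 5.79, the higher of the two numbers. Compound 2, which carries two propyl groups on the shared core, gives 4.44; the gap between the two values lies beyond the usual scatter, so compound 1 is the more potent of the pair.

The unmeasured compound 3 `CC1=C(N2CC2)C(=O)C(C(C)COC(N)=O)=C(N2CC2)C1=O` is an isomer of compound 1 with the same atoms joined differently: a group of 7 heavy atoms (4 carbon, 1 nitrogen, 2 oxygen; no ring) in place of a group of 7 heavy atoms (4 carbon, 1 nitrogen, 2 oxygen; no ring), on a double-bonded ring carbon. Among the measured compounds shown here, both side chains retain the carbamate with its single hydrogen-bond donor and two acceptors, and the core is unchanged, so no step of the size seen between compound 1 and compound 2 is expected here. A step of a number 0.29 log units lower from compound 1 to compound 3 (within the scatter) in this assay is expected, a small loss that may fall within the scatter. Compound 3 is estimated at 5.5, within a range of 4.9 to 6.1.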

Compound 3, logarithm of the reciprocal of the active concentration, log(1/C): 5.71
Estimate against measurement, compound 3: 0.21 log units below, and the stated range covers the measured number.
By their numbers in this assay, from the lowest: compound 2; then compounds 3 and 1 (each within the scatter of the next).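

At the double-bonded ring carbon, moving the branch within the carbamate-bearing side chain gives a number 0.08 log units lower from compound 1 to compound 3 (within the scatter) in this assay, so the two isomers cannot be told apart in this assay. With the core and the atoms of the side chain held constant, this position therefore tolerates this particular rearrangement, something the earlier pair could not show, as compound 1 and compound 2 differ in more than one place. Nothing available here explains why the two isomers read alike.

The compounds shown leave open what the carbamate itself contributes, as no pair differs only by its presence at this carbon. Going by these compounds, whether an amine, a carboxylic acid or a longer chain at the same carbon would keep the value of compound 1 also remains open.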